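The source may report more compounds than this note shows. Statements on the series, on what has been measured and on what is new or still open speak of the compounds shown alone.

Measured so far in an ADME assay on SW480 cells (Homo sapiens) for cytotoxicity, read by MTT assay, with a stated time of 72 h; a higher number here means a weaker inhibitor, a lower number a stronger inhibitor:

Compound 1 `CCCCCN1C(=O)C/C(=C\c2cccc(C(=O)Nc3ccc(C)cc3)c2)C1=O`: > 100000 nM, a limit of the assay rather than a number.
Compound 2 `Cc1ccc(N2C(=O)C/C(=C\c3cccc(C(=O)Nc4cccc(F)c4)c3)C2=O)cc1`: 96900 nM.
Compound 3 `Cc1cccc(NC(=O)c2cccc(/C=C3\CC(=O)N(c4ccccc4)C3=O)c2)c1`: > 100000 nM, again a limit of the assay rather than a number.

All three compounds share one core and differ only in the groups hung on it. None of them shows a clear effect on the cells within the tested range. Compound 3 stands at the limit of > 100000 nM in this assay, at which 2 of the 3 values shown sit. The value of compound 2 is close to that limit and falls within the usual scatter of it, so no order between these compounds can be read from the numbers.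

The next compound to be measured is compound 4 `O=C(c1cccc(/C=C2\CC(=O)N(c3ccccc3)C2=O)c1)N1CCCC1`. It differs from compound 3 in one place: pyrrolidin-1-yl in place of (3-methylphenyl)amino on a carbonyl carbon. Among the compounds with values here, no step between two measured compounds is available to show how such a change plays out here, so the expectation rests on the three results alone, which all lie at or near the limit of the assay. The step from compound 3 to compound 4 is expected to be none beyond the scatter, and the estimated change is a number no higher from compound 3 to compound 4 (the limit leaves the size open). Compound 4 is therefore expected to come out at about 100000 nM, with a plausible range from 40000 nM to 300000 nM, most likely reported again only as a limit.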

Compound 4, half-maximal inhibitory concentration: > 100000 nM
Compound 4 was reported as a limit; the forecaster's own chance of this, stated with the estimate: 70%; the middle value lies on the limit itself.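

In this assay compound 4 gives > 100000 nM, a limit of the assay and not a number. Compound 3 also carries a limit, so no step can be read from compound 3 to compound 4. Compound 4 joins the values at that limit: the limit of > 100000 nM in this assay, at which 3 of the 4 values shown sit.

The compounds shown leave open which change to the shared core, if any, would give a clear effect on these cells.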